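Working notes: step from compound 3 to compound 4

The source may hold more compounds than are shown below. What is called first, only, known or untested is meant among the compounds shown, and "the series" means these compounds.

Measured compounds:
compound 1 `Nc1ccccc1NC(=O)c1ccc(CSC(=S)N2CCN(c3ccc(Cl)cc3)CC2)cc1`: 15%
compound 2 `Nc1ccccc1NC(=O)c1ccc(CSC(=S)N2CCN(Cc3cccnc3)CC2)cc1`: 37.7%
compound 3 `Nc1ccccc1NC(=O)c1ccc(CSC(=S)N2CCN(c3ccccc3F)CC2)cc1`: 33.7%

In a functional assay on MGC-803 cells (Homo sapiens) for antiproliferative activity, read by CCK-8 assay, with a stated time of 72 h, tested at 2 uM (on this read-out lower numbers stand for a weaker effect and higher numbers for a stronger effect at the one concentration tested), compound 3 stands second highest of the three. Its nearest neighbour is compound 2: the step of a number 4 percentage points lower from compound 2 to compound 3 (within the scatter) lies within the scatter, so no order between the two is claimed. Its furthest neighbour is compound 1: the step of a number 18.7 percentage points higher from compound 1 to compound 3 (beyond the scatter) is beyond the scatter, as is a number 22.7 percentage points higher from compound 1 to compound 2 (beyond the scatter); both steps replace 4-chlorophenyl on the ring nitrogen and both raise the read-out modestly.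

Compound 4 `Nc1ccccc1NC(=O)c1ccc(CSC(=S)N2CCN(Cc3ccccc3)CC2)cc1` differs from compound 3 as follows: benzyl in place of 2-fluorophenyl on an amine nitrogen in a ring. Among the compounds with values here, no measured step introduces benzyl, so the bearing steps are indirect. The step of a number 4 percentage points lower from compound 2 to compound 3 (within the scatter) shows that exchanging one ring-bearing group for another at this nitrogen, away from 4-chlorophenyl, moved the read-out only within the scatter. On that basis the expected step of a number 0.7 percentage points lower from compound 3 to compound 4 (within the scatter) is within the scatter, in no firm direction. Compound 4 is therefore estimated at 33%, with a range from 20% to 46%.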

Compound 4, a percentage reported as inhibition, at one concentration (the size of the read-out at that concentration, not a potency): 18.1%
The estimate for compound 4 lay 14.9 percentage points above the measured number; the measured number lies below the stated range.
By their numbers in this assay, from the lowest: compounds 1 and 4 (each within the scatter of the next); then compounds 3 and 2 (each within the scatter of the next).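

The benzyl group on the amine nitrogen in a ring breaks the earlier picture of a flat response at this position away from 4-chlorophenyl, in this assay giving a number 15.6 percentage points lower from compound 3 to compound 4 (beyond the scatter), and the nature of the ring on the saturated chain carbon counts as well, with phenyl in place of pyridin-3-yl giving a number 19.6 percentage points lower from compound 2 to compound 4 (beyond the scatter). Benzyl and 4-chlorophenyl are not separated, the step being a number 3.1 percentage points higher from compound 1 to compound 4 (within the scatter), so an aromatic ring carried through a saturated chain carbon does not by itself hold the read-out at the level of compound 2. Nothing at hand accounts for these steps.

Open, as far as these compounds go, is whether a 2-fluorobenzyl group would read like compound 3 or like compound 4. Also open, from the compounds shown here alone, is whether (pyridin-4-yl)methyl or (pyridin-2-yl)methyl would stay level with compound 2.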